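From 4-aminophenyl to 3,4-difluorophenyl at the assay limit

The source may hold more compounds than are shown below. What is called first, only, known or untested is meant among the compounds shown, and "the series" means these compounds.

Measured compounds and their values
compound 1 (`COc1cc(-c2cc(/C=C/C(=O)c3ccc(N)cc3)[nH]n2)cc(OC)c1OC`) gives > 100000 nM
compound 2 (`COc1ccc(C(=O)/C=C/c2cc(-c3cc(OC)c(OC)c(OC)c3)n[nH]2)cc1OC`) gives > 100000 nM

In a functional assay on K562 cells (Homo sapiens) for inhibition, read by sulforhodamine B assay, with a stated time of 48 h (on this read-out higher numbers stand for lower toxicity in this test and lower numbers for higher toxicity in this test), compound 1 stands at > 100000 nM as a limit and not a number. Compound 2 stands at > 100000 nM as a limit too. All the measured data therefore amount to the limit of > 100000 nM in this assay, at which 2 of the 2 values shown sit, with no true value behind it. The change to compound 3 (`COc1cc(-c2cc(/C=C/C(=O)c3ccc(F)c(F)c3)[nH]n2)cc(OC)c1OC`) is 3,4-difluorophenyl in place of 4-aminophenyl on a carbonyl carbon with the core of compound 1 kept. Going by the values given here, the only measured step at this place is a step that the two limits leave unreadable from compound 1 to compound 2 for 3,4-dimethoxyphenyl in place of 4-aminophenyl, and it offers no size to carry over. No step beyond the scatter is therefore expected in this assay and no direction can be given. The step expected is a number no higher from compound 1 to compound 3 (the limit leaves the size open) and it is an estimate only. For compound 3 the estimate is 100000 nM with an expected range from 30000 nM to 300000 nM and a reading at the same limit is likely.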

Compound 3, concentration lethal to 50% of the cells: > 100000 nM
Compound 3: a limit, no number (the forecaster's own chance of this, stated with the estimate: 75%); the middle value sits exactly at the limit.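

No step can be read among compound 1, compound 2 and compound 3 in this assay, since all three values are limits and not numbers: the limit of > 100000 nM in this assay, at which 3 of the 3 values shown sit. The compounds shown leave open whether changing the group on the carbonyl carbon alters toxicity in this test at all.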